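The compounds below may be only part of what the source reports. "The series", "measured", "known", "first", "only" and "open" are said of these compounds alone.

In a functional assay on A549 cells (Homo sapiens) for cytotoxicity (on this read-out higher numbers stand for weaker inhibition and lower numbers for stronger inhibition), two compounds have been measured so far. Compound 1 (`COc1cc(/C=C/c2ccc3ccccc3n2)cc(OC)c1OC`) gives 398 nM, and compound 2 (`COc1cc(/C=C\c2ccc3nccnc3c2)cc(OC)c1OC`) gives 7940 nM, the higher of the two numbers and so the weaker inhibition, with a gap beyond the scatter. Compound 3 (`COc1cc(/C=C/c2ccc3nccnc3c2)cc(OC)c1OC`) has not yet been measured. It relates to compound 2 as follows: the two compounds have the same atoms and bonds and differ only in configuration as drawn: 1 of 1 stereo elements differ; a double bond is drawn Z in compound 2 and E in compound 3. Among the measured compounds shown here, no measured pair shows what such a change does in this assay, so the expectation rests only on the two values at hand. Compound 1, at 398 nM, shows that lower numbers can be reached here, which tilts the expectation modestly downward, although a result within the scatter of compound 2 remains possible. The estimated change is a 2.6-fold lower number from compound 2 to compound 3 (0.42 log units; beyond the scatter). For compound 3 the expected value is 3000 nM, with an estimated range of 600 nM to 15000 nM.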

Compound 3, half-maximal inhibitory concentration: > 15800 nM
Compound 3 gave a limit, no number; the forecaster's own chance of this, stated with the estimate: 15%; middle value at least 5.2-fold (0.72 log units) from the limit.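

In this assay compound 3 gives > 15800 nM, which is a limit of the assay and not a number. Turning the double bond from Z to E is a change that no earlier pair had covered, and it comes out as an at least 1.9-fold higher number from compound 2 to compound 3 (0.29 log units; that floor lies within the scatter), so this switch brought no lower number and the expected gain did not appear. Whatever separates the two compounds can lie only in the drawn configuration of that double bond: the fact that compounds 2 and 3 differ only in the configuration as drawn

From the compounds shown here alone, how far compound 3 really lies from compound 2 stays open, since the limit gives only a floor for the step, and that floor does not by itself establish a real difference. Also open, going by these compounds, is what an amine or a carboxylic acid on the shared core would do to the number in this assay.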